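This account rests on a few compounds, and the source may have more. Where it says the series, first, only, none or still open, it means among the compounds named here.

The measured compounds are:
compound 1, `CC(O)(CSc1ccc(C(F)(F)F)cc1)C(=O)Nc1ccc(S(F)(F)(F)(F)F)cc1`, with 28800 nM;
compound 2, `CC(O)(CSc1cccc(C(F)(F)F)c1)C(=O)Nc1ccc(S(F)(F)(F)(F)F)cc1`, with 26200 nM;
compound 3, `CC(O)(CSc1ccc(C(F)(F)F)cc1)C(=O)Nc1cccc(S(F)(F)(F)(F)F)c1`, with 27200 nM.

All three numbers come from a functional assay on DU-145 cells (Homo sapiens) for antiproliferative activity, read by propidium iodide staining, with a stated time of 96 h; a higher number here means a weaker inhibitor, a lower number a stronger inhibitor. Compound 2 arises from compound 1 by a single change, (3-(trifluoromethyl)phenyl in place of 4-(trifluoromethyl)phenyl on a sulfur), and that change gave a 1.1-fold lower number from compound 1 to compound 2 (0.04 log units; within the scatter). Compound 4, `CC(O)(CSc1cccc(C(F)(F)F)c1)C(=O)Nc1cccc(S(F)(F)(F)(F)F)c1`, has not yet been measured; it arises from compound 3 by the same change, (3-(trifluoromethyl)phenyl in place of 4-(trifluoromethyl)phenyl on a sulfur), at the same place. The difference between the core of compound 1 and the core of compound 3 is not broken down here. The step from compound 3 to compound 4 is expected to be of similar size, a 1.1-fold lower number from compound 3 to compound 4 (0.04 log units; within the scatter). That expectation rests on compound 1 and compound 2, where the change gave a 1.1-fold lower number from compound 1 to compound 2 (0.04 log units; within the scatter), a step within the scatter. Compound 4 is therefore estimated to give 25000 nM in this assay, most likely between 12000 nM and 50000 nM.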

Compound 4, half-maximal inhibitory concentration: 19100 nM
Estimate against measurement, compound 4: 1.3-fold (0.12 log units) above; the range from low to high includes it.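

In this assay, putting 3-(trifluoromethyl)phenyl in place of 4-(trifluoromethyl)phenyl on a sulfur gave a 1.4-fold lower number from compound 3 to compound 4 (0.15 log units; within the scatter). Set beside the earlier step, the change behaves alike on the two cores, with no difference that can be told from ordinary assay noise: the same change on two cores in this assay, a 1.1-fold lower number (0.04 log units; within the scatter) from compound 1 to compound 2 and a 1.4-fold lower number (0.15 log units; within the scatter) from compound 3 to compound 4, 1.3-fold (0.11 log units) apart, within the scatter of two such steps. This does not show that the change truly lowers the number, nor that it would behave the same way on any core beyond these two.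

The compounds shown leave open what a group other than trifluoromethyl, such as a nitrile or a carboxylic acid, would do on that ring. They also leave open what an amine in place of the sulfur would do.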